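From 3-fluoro-4-methoxyphenyl to 2,3-dimethylphenyl on the shared core

A few compounds are considered here, and "the series" means these few. Any claim that something is new, unique, unknown or untested is made for them only; others in the source may bear on it.

Compound 1 `CCC1=C(O)c2c(oc(-c3ccccc3F)cc2=O)C(CC)(CC)C1=O` with 3.93 uM
Compound 2 `CCC1=C(O)c2c(oc(-c3ccc(OC)cc3C)cc2=O)C(CC)(CC)C1=O` with 2.62 uM
Compound 3 `CCC1=C(O)c2c(oc(-c3ccc(OC)c(F)c3)cc2=O)C(CC)(CC)C1=O` with 0.1 uM

These values come from a functional assay on KBVIN cells (Homo sapiens) for antiproliferative activity, read by sulforhodamine B assay, with a stated time of 3 days (on this read-out higher numbers stand for an effect only at larger amounts of compound and lower numbers for an effect already at smaller amounts), and compound 3 has the lowest number of the three. Compound 4 `CCC1=C(O)c2c(oc(-c3cccc(C)c3C)cc2=O)C(CC)(CC)C1=O` differs from it by 2,3-dimethylphenyl in place of 3-fluoro-4-methoxyphenyl on an aromatic carbon on the same aromatic carbon. Two large measured steps bear on this change (the first is a 39-fold lower number from compound 1 to compound 3 (1.59 log units; beyond the scatter) and the second is a 26-fold lower number from compound 2 to compound 3 (1.42 log units; beyond the scatter)). Both bring in the group that compound 4 gives up. The remaining step is small (a 1.5-fold lower number from compound 1 to compound 2 (0.18 log units; within the scatter)). For the measured compounds named here, no measured compound carries 2,3-dimethylphenyl, so a large step to a higher number is expected in this assay on that evidence alone. The estimated change is a 30-fold higher number from compound 3 to compound 4 (1.48 log units; beyond the scatter) in that direction. For compound 4 the estimated value is 3 uM within an expected range from 0.8 uM to 10 uM as its span.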

Compound 4, concentration for half-maximal effect: 0.85 uM
Compound 4: middle estimate off by 3.5-fold (0.55 log units), on the high side; the measured number falls inside the stated range.
By their numbers in this assay, from the lowest: compound 3; then compound 4; then compounds 2 and 1 (each within the scatter of the next).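

In (this assay), the carbon-only 2,3-dimethylphenyl ranks clearly ahead of both groups that compound 4 shares its place with at the weak end, 4-methoxy-2-methylphenyl (a 3.1-fold lower number from compound 2 to compound 4 (0.49 log units; beyond the scatter)) and 2-fluorophenyl (a 4.6-fold lower number from compound 1 to compound 4 (0.66 log units; beyond the scatter)). It still falls short of 3-fluoro-4-methoxyphenyl (an 8.5-fold higher number from compound 3 to compound 4 (0.93 log units; beyond the scatter)), so a group with no oxygen or fluorine keeps part of the gain seen with compound 3. No supporting measurement explains this order. Open, as far as these compounds go, is how this position would respond to an aminophenyl or a carboxylic acid-bearing phenyl, or to a longer chain such as hexyl.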